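This account rests on a few compounds, and the source may have more. Where it says the series, first, only, none or still open, it means among the compounds named here.

Measured compounds:
Compound 1, `Cc1ccc2nc(N3CCCc4ccc(F)cc4C3)cc(NCCN(C)C)c2c1`: in an ADME assay on HEp-2 cells (Homo sapiens) for cytotoxicity, read by CCK-8 assay, with a stated time of 5 days (a higher number here means that more compound is tolerated, a lower number that less compound is tolerated), compound 1 gives 89000 nM.
Compound 2, `Cc1ccc2nc(N3CCCc4ccc(F)cc4C3)cc(NC(C)(C)CN)c2c1`: compound 2 gives 25000 nM.
Compound 3, `Cc1ccc2nc(N3CCCc4ccc(F)cc4C3)cc(NCC3CCCCN3)c2c1`: compound 3 gives 23000 nM.

Compound 3 stands at the lowest of the three numbers, but its gap to compound 2, a 1.1-fold lower number from compound 2 to compound 3 (0.04 log units; within the scatter), lies within the scatter, so the two cannot be told apart. Compound 1 stands clearly apart from both, as shown by a 3.9-fold lower number from compound 1 to compound 3 (0.59 log units; beyond the scatter) and a 3.6-fold lower number from compound 1 to compound 2 (0.55 log units; beyond the scatter).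

Compound 4, `Cc1ccc2nc(N3CCCc4ccc(F)cc4C3)cc(NC3(CN)COC3)c2c1`, differs from compound 3 in one place: 3-(aminomethyl)oxetan-3-yl in place of (piperidin-2-yl)methyl on a nitrogen on an aromatic ring. Within the data shown here, two measured steps bear on this exchange. The step from compound 2 to compound 3 swaps a group carrying an aminomethyl for a ring-bound amine and stays within the scatter, while the steps out of compound 1 show that a change at this position can move the number modestly. Compound 4 keeps an aminomethyl, like compound 2, and a small ring, like compound 3, so a step within the scatter is expected, a 1.2-fold higher number from compound 3 to compound 4 (0.09 log units; within the scatter). On that basis compound 4 is estimated to give 28000 nM in this assay, with an expected range from 11000 nM to 75000 nM.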

Compound 4, half-maximal cytotoxic concentration: 86000 nM
For compound 4 the middle estimate is 3.1-fold (0.49 log units) below the measured one, and the stated range ends below it.
By their numbers in this assay, from the lowest: compounds 3 and 2 (each within the scatter of the next); then compounds 4 and 1 (each within the scatter of the next).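

In this assay, keeping the aminomethyl does not fix the number at this position: a 3.4-fold higher number from compound 2 to compound 4 (0.54 log units; beyond the scatter) shows that exchanging 1-(aminomethyl)-1-methylethyl for 3-(aminomethyl)oxetan-3-yl on the same nitrogen is enough to move it beyond the scatter, and a 3.7-fold higher number from compound 3 to compound 4 (0.57 log units; beyond the scatter) shows a step of similar size when the same group replaces (piperidin-2-yl)methyl. The earlier compounds shown here suggested that only 2-(dimethylamino)ethyl stood apart, but a 1.0-fold lower number from compound 1 to compound 4 (0.01 log units; within the scatter) places compound 4 level with compound 1, so two quite different groups now share the more tolerated end of this small set. Nothing available explains why these exchanges give these numbers.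

The compounds shown leave open whether the step from compound 2 to compound 4 goes with the oxygen or with the four-membered ring itself, a question that an aminomethyl on a cyclobutane ring, with carbon in place of that oxygen, could address. They also leave open whether the primary amine matters in the oxetane group, which a hydroxymethyl in place of the aminomethyl could test.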